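The source may report more compounds than this note shows. Statements on the series, on what has been measured and on what is new or still open speak of the compounds shown alone.

Of the compounds shown here, three sharing one core have been tested in a functional assay on MDA-MB-231 cells (Homo sapiens) for antiproliferative activity, read by MTT assay; on this read-out higher numbers stand for weaker inhibition and lower numbers for stronger inhibition. Compound 1, with the structure `CNC(=O)c1ccc(Oc2cccc(NC(=S)Nc3ccc(OC(F)(F)F)cc3)c2)nc1`, gives 56000 nM. Compound 2, with the structure `CNC(=O)c1ccc(Oc2cccc(NC(=S)Nc3ccc(Cl)cc3Cl)c2)nc1`, gives 20700 nM. Compound 3, with the structure `CNC(=O)c1ccc(Oc2cccc(NC(=S)Nc3ccc(Cl)c(C(F)(F)F)c3)c2)nc1`, gives 2330 nM. Compound 3 thus has the lowest number of the three, and so the strongest inhibition: its nearest neighbour is compound 2, whose number lies beyond the scatter above it, and compound 1 lies further still.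

Compound 4, with the structure `CNC(=O)c1ccc(Oc2cccc(NC(=S)Nc3ccc(Cl)cc3)c2)nc1`, has not yet been measured in this assay. It differs from compound 3 in one place: hydrogen in place of trifluoromethyl on an aromatic carbon. Among the measured compounds shown here, the trifluoromethyl group that leaves is the only feature that sets compound 3 apart from the other two in this way, and both of those give clearly higher numbers. For the measured compounds named here, no direct pair in the measured data isolates this exact change, so the expectation rests on the overall picture. The step from compound 3 to compound 4 is expected to be a 5.2-fold higher number from compound 3 to compound 4 (0.71 log units; beyond the scatter), towards weaker inhibition. Compound 4 is estimated to give 12000 nM, within a range from 4000 nM to 40000 nM.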

Compound 4, half-maximal inhibitory concentration: 66500 nM
Beside the measured number, compound 4's estimate is 5.5-fold (0.74 log units) below it, outside the stated range (above it).
By their numbers in this assay, from the lowest: compound 3; then compound 2; then compounds 1 and 4 (each within the scatter of the next).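

In this assay, the trifluoromethyl group on this aromatic carbon, ortho to a chloro group, proves decisive, since replacing it with hydrogen gives a 29-fold higher number from compound 3 to compound 4 (1.46 log units; beyond the scatter), so compound 3 owes its low number largely to this one group. Other single changes count for less: hydrogen in place of chloro gives a 3.2-fold higher number from compound 2 to compound 4 (0.51 log units; beyond the scatter), and chloro in place of trifluoromethoxy gives a 1.2-fold higher number from compound 1 to compound 4 (0.07 log units; within the scatter), so those two compounds cannot be told apart. Nothing available explains why trifluoromethyl matters so much at this carbon.

On these data alone, whether a methyl group, a nitrile or an amine on the same carbon could keep the number as low remains open. Also open, as far as these compounds go, is whether trifluoromethyl would have the same effect without the chloro group ortho to it.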